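Cytotoxicity notes on the aryl ether series, compound 3 to compound 4

The source may hold more compounds than are shown below. What is called first, only, known or untested is meant among the compounds shown, and "the series" means these compounds.

Measured so far:
compound 1 `COc1ccc(Oc2nc(Nc3ccc(C#N)cc3)nc3ccccc23)cc1` gives 340000 nM in an ADME assay on MT4 cells (Homo sapiens) for cytotoxicity, read by MTT assay, with a stated time of 4 days; a lower number here means that less compound is tolerated, a higher number that more compound is tolerated
compound 2 `N#Cc1ccc(Nc2nc(Oc3ccc(Cl)cc3)c3ccccc3n2)cc1` gives 198000 nM in this assay
compound 3 `N#Cc1ccc(Nc2nc(Oc3ccc(Br)cc3)c3ccccc3n2)cc1` gives 215000 nM in this assay

All three numbers sit within the scatter of one another, so no order among them can be read. Compound 3 stands second highest of the three, nearest compound 2 and furthest from compound 1, each gap within the scatter.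

Compound 4 `COc1cc(C#N)ccc1Oc1nc(Nc2ccc(C#N)cc2)nc2ccccc12` has not been measured. Its change from compound 3: 4-cyano-2-methoxyphenyl in place of 4-bromophenyl on an oxygen on an aromatic ring. Among the measured compounds shown here, the steps that bear on it are a 1.6-fold lower number from compound 1 to compound 3 (0.20 log units; within the scatter) and a 1.1-fold higher number from compound 2 to compound 3 (0.04 log units; within the scatter), both within the scatter; they cover bromo against methoxy and bromo against chloro on an aromatic carbon, but no measured step adds a nitrile to this ring. The exchange of a halogen for a methoxy on this ring gave nothing beyond the scatter, so in this assay the expected step is a 1.2-fold higher number from compound 3 to compound 4 (0.07 log units; within the scatter), no direction beyond the scatter. Compound 4 is therefore estimated at 250000 nM, between 100000 nM and 500000 nM.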

Compound 4, half-maximal cytotoxic concentration: >= 140000 nM
Compound 4 gave a limit, no number (the forecaster's own chance of this, stated with the estimate: 25%); the middle value is on the limit's open side.
By their numbers in this assay, from the lowest: compounds 2, 3 and 1 (each within the scatter of the next).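

Compound 4 gives >= 140000 nM in this assay, a limit of the assay and not a number. Among the compounds shown here, no step from compound 1, compound 2 or compound 3 to compound 4 can be read. The compounds shown leave open what 4-cyano-2-methoxyphenyl in place of 4-bromophenyl does to the number in this assay.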